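The compounds below may be only part of what the source reports. "The series", "measured", "known", "first", "only" and "open" are said of these compounds alone.

The compounds share one core, and what varies is the aryl group attached to a carbon with a double bond to nitrogen. Compound 1 `Nc1nc(N/N=C/c2ccc3ncccc3c2)nc2c1ncn2[C@@H]1O[C@H](CO)[C@@H](O)[C@H]1O` carries quinolin-6-yl there; in an assay on CHO-K1 cells for displacement of a labelled ligand from adenosine receptor A1 (Homo sapiens), read by scintillation counting, with a stated time of 60 min (on this read-out lower numbers stand for stronger inhibition and higher numbers for weaker inhibition), compound 1 gives 9.8 nM. Compound 2 `Nc1nc(N/N=C/c2cccnc2Cl)nc2c1ncn2[C@@H]1O[C@H](CO)[C@@H](O)[C@H]1O` carries 2-chloropyridin-3-yl in the same place, and in this assay compound 2 gives 4.6 nM, the lowest of the two numbers recorded so far; the move was a 2.1-fold lower number from compound 1 to compound 2 (0.33 log units; beyond the scatter). Compound 3 `Nc1nc(N/N=C/c2ccc(N3CCCC3)cc2)nc2c1ncn2[C@@H]1O[C@H](CO)[C@@H](O)[C@H]1O` has not yet been measured. It differs from compound 2 in one place: 4-(pyrrolidin-1-yl)phenyl in place of 2-chloropyridin-3-yl on a carbon with a double bond to nitrogen. Within the data shown here, only one measured step bears on this change, a 2.1-fold lower number from compound 1 to compound 2 (0.33 log units; beyond the scatter), and that swapped one six-membered aromatic ring with 1 hetero atom for another; the entering 4-(pyrrolidin-1-yl)phenyl has no comparator among the measured compounds. A step of comparable size in either direction, or none beyond the scatter, is plausible. Compound 3 is therefore expected in this assay to give about 8 nM, with a range from 2.5 nM to 30 nM. This estimate means an expected step of a 1.7-fold higher number from compound 2 to compound 3 (0.24 log units; within the scatter), a slight loss rather than a gain.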

Compound 3, inhibition constant: 5.1 nM
The estimate for compound 3 lay 1.6-fold (0.20 log units) above the measured number; measured number inside the range.
By their numbers in this assay, from the lowest: compounds 2, 3 and 1 (each within the scatter of the next, the first and the last beyond it).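

In this assay, the place on a carbon with a double bond to nitrogen takes 4-(pyrrolidin-1-yl)phenyl, with 11 heavy atoms and a five-membered non-aromatic ring joined to a six-membered aromatic ring of carbon only, in place of 2-chloropyridin-3-yl, with 7 heavy atoms, at a 1.1-fold higher number from compound 2 to compound 3 (0.04 log units; within the scatter). Set against the quinolin-6-yl compound, the same group gives a 1.9-fold lower number from compound 1 to compound 3 (0.28 log units; within the scatter), so compound 3 cannot be told apart from either of the two earlier compounds, although those two differ from each other beyond the scatter. Among these compounds, neither chlorine nor a hetero atom in the aromatic ring is required for a number in this range, but nothing available explains why such different groups give such close numbers.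

Going by these compounds, what the pyrrolidine ring itself contributes stays open, and a plain phenyl group or a piperidine ring in the same setting would speak to that. Also open is how the number responds to a carboxylic acid or a primary amine on the aryl group, since the three groups shown carry neither.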